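Changing the link on compound 2

The source may report more compounds than this note shows. Statements on the series, on what has been measured and on what is new or still open speak of the compounds shown alone.

Within the data shown here, in a functional assay on MCF7 cells (Homo sapiens) for cytotoxicity, read by sulforhodamine B assay, with a stated time of 72 h (a higher number here means a weaker inhibitor, a lower number a stronger inhibitor), compound 2 `O=C(Nc1ccc(Nc2ncnc3c2cnn3-c2ccc(Cl)cc2)cc1)Nc1ccccc1Cl` gives the lowest number so far, at 9050 nM. Compound 3 `O=c1sc2cc(Nc3ncnc4c3cnn4-c3ccccc3)ccc2n1Cc1ccc(Cl)cc1Cl` gives 44000 nM and compound 1 `O=C(Nc1ccc(Nc2ncnc3c2cnn3-c2ccccc2)cc1)Nc1ccccc1Cl` gives 55100 nM, both higher. Compound 4 `O=C(Nc1ccccc1Cl)c1ccc(Nc2ncnc3c2cnn3-c2ccc(Cl)cc2)cc1` alters a single place in compound 2: (2-chlorophenyl)carbamoyl in place of ((2-chlorophenyl)carbamoyl)amino on an aromatic carbon. Among the measured compounds shown here, the only measured step, a 6.1-fold lower number from compound 1 to compound 2 (0.78 log units; beyond the scatter), came with chloro in place of hydrogen on an aromatic carbon, and compound 4 keeps that chloro. For the measured compounds named here, no measured step covers the present change, so neither direction is favoured and no step beyond the scatter is expected. The expected step is a 1.2-fold higher number from compound 2 to compound 4 (0.08 log units; within the scatter). Compound 4 is estimated at 11000 nM, with an expected range of 3500 nM to 35000 nM.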

Compound 4, half-maximal inhibitory concentration: > 100000 nM
Compound 4: a limit, no number; the forecaster's own chance of this, stated with the estimate: 10%; middle value at least 9.0-fold (0.95 log units) away from the limit.
By their numbers in this assay, from the lowest: compound 2; then compounds 3 and 1 (each within the scatter of the next). At a limit, above all of these: compound 4.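

In this assay, the link at this position matters: (2-chlorophenyl)carbamoyl in place of ((2-chlorophenyl)carbamoyl)amino gives an at least 11-fold higher number from compound 2 to compound 4 (1.04 log units; beyond the scatter), a large step, even though the chloro that accompanied the earlier step stays in place. Among these compounds, the only earlier step involved that chloro, so this is the first measured change at this link. The result for compound 4 is a limit, not a number: the limit of > 100000 nM in this assay, at which 1 of the 4 values shown sits.

From the compounds shown here alone, how far beyond that limit compound 4 lies remains unknown. Going by these compounds, whether a sulfonamide or a plain amine at this position would keep the number of compound 2 also remains open.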